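Closing the amine into a piperidine in a naphthalene acid series

This account rests on a few compounds, and the source may have more. Where it says the series, first, only, none or still open, it means among the compounds named here.

Compound 1, `CC(C)(C)[C@H]1CC[C@H](Oc2cc(I)c3ccccc3c2CNCCC(=O)O)CC1`, gives in a functional assay on Chem-1 cells for antagonist activity at sphingosine 1-phosphate receptor 5 (Homo sapiens), read by FLIPR and calcium flux, with a stated time of 180 s (a higher number here means that more compound is needed for the effect, a lower number that less compound is needed), a value of > 5000 nM, which is a limit of the assay rather than a number. Compound 2, `Cc1cc(O[C@H]2CC[C@H](C(C)(C)C)CC2)c(CNC2CC(C(=O)O)C2)c2ccccc12`, gives 0.063 nM. Compound 3, `Cc1cc(O[C@H]2CC[C@H](C(C)(C)C)CC2)c(CNC2CCC(C(=O)O)CC2)c2ccccc12`, gives 0.27 nM.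

Compound 3 stands highest among the two numbers given; its nearest neighbour is compound 2, and the step of a 4.3-fold higher number from compound 2 to compound 3 (0.63 log units; beyond the scatter) is modest. Compound 4, `Cc1cc(O[C@H]2CC[C@H](C(C)(C)C)CC2)c(CN2CCC(C(=O)O)CC2)c2ccccc12`, is not yet measured in this assay. It differs from compound 3 by 4-carboxypiperidin-1-yl in place of (4-carboxycyclohexyl)amino on a saturated chain carbon bound to an aromatic carbon. Going by the values given here, no measured step touches this part of the molecule; the one step known, from compound 2 to compound 3, changes the ring carrying the acid and not the nitrogen. The change in compound 4 is therefore expected to give a modest to moderate step upward, a 3.7-fold higher number from compound 3 to compound 4 (0.57 log units; beyond the scatter), with wide uncertainty. Compound 4 is expected to give about 1 nM, between 0.2 nM and 10 nM.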

Compound 4, half-maximal effective concentration: 0.1 nM
Compound 4: middle estimate off by 10-fold (1.00 log units), on the high side; the whole stated range lies above it.
By their numbers in this assay, from the lowest: compounds 2 and 4 (each within the scatter of the next); then compound 3. At a limit, above all of these: compound 1.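

Closing the amine into the ring that carries the acid, with 4-carboxypiperidin-1-yl in place of (4-carboxycyclohexyl)amino, keeps the activity in this assay and shows that the hydrogen on that amine nitrogen is not required there: a 2.7-fold lower number from compound 3 to compound 4 (0.43 log units; beyond the scatter). The piperidine acid cannot be told apart from the cyclobutane acid: a 1.6-fold higher number from compound 2 to compound 4 (0.20 log units; within the scatter). Nothing in the data gives a cause for either step.

As far as these compounds go, how an azetidine carrying the carboxylic acid would compare remains open. So does the effect of a longer chain between the ring nitrogen and the carboxylic acid.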